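Compound 1 to compound 4: fluoro in place of methoxy

A few compounds are considered here, and "the series" means these few. Any claim that something is new, unique, unknown or untested is made for them only; others in the source may bear on it.

Going by the values given here, in a functional assay on NCI-H460 cells (Homo sapiens) for antiproliferative activity, with a stated time of 72 h (on this read-out higher numbers stand for weaker inhibition and lower numbers for stronger inhibition), compound 1 (`C=CC[C@H]1C[C@]2([C@@H](C)Cc3ccc(OC)c(OC)c3)OCOC2=CC1=O`) gives 260 nM, the only number in this set. Compound 2 (`C=CC[C@@H]1C[C@]2([C@@H](C)Cc3ccc(OC)c(OC)c3)OCOC2=CC1=O`) reads > 4000 nM, which is a limit of the assay. Compound 3 (`C=CC[C@@H]1C[C@]2([C@H](C)Cc3ccc(OC)c(OC)c3)OCOC2=CC1=O`) reads > 4000 nM, which is also a limit. The measured steps are an at least 15-fold higher number from compound 1 to compound 2 (1.18 log units; beyond the scatter) and an at least 15-fold higher number from compound 1 to compound 3 (1.18 log units; beyond the scatter), both large, alongside a step that the two limits leave unreadable from compound 2 to compound 3. All three concern configuration alone, as shown by the fact that compounds 1 and 2 differ only in the configuration as drawn, the fact that compounds 1 and 3 differ only in the configuration as drawn and (the fact that compounds 2 and 3 differ only in the configuration as drawn).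

Compound 4 (`C=CC[C@H]1C[C@]2([C@@H](C)Cc3ccc(OC)c(F)c3)OCOC2=CC1=O`) keeps the configuration of compound 1 and changes the aromatic ring instead: fluoro in place of methoxy on an aromatic carbon. This is fluoro in place of methoxy on an aromatic carbon, ortho to a methoxy group. Among the compounds with values here, no measured step touches this ring, so the series gives no direct size for the change. Compound 4 shares its configuration with compound 1, so a collapse like an at least 15-fold higher number from compound 1 to compound 2 (1.18 log units; beyond the scatter) is not expected on that ground. A modest move towards a higher number in this assay is expected, possibly not beyond the scatter, and this expectation is weakly founded. The expected step is a 1.9-fold higher number from compound 1 to compound 4 (0.28 log units; within the scatter). For compound 4 the estimated value is 500 nM, with an expected range of 150 nM to 2500 nM.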

Compound 4, half-maximal inhibitory concentration: 90 nM
Beside the measured number, compound 4's estimate is 5.6-fold (0.74 log units) above it; measured number below the stated range.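

In this assay, going by these compounds alone, the first measured change on the aromatic ring gives a 2.9-fold lower number from compound 1 to compound 4 (0.46 log units; beyond the scatter), with fluoro in place of methoxy at the place ortho to a methoxy group. The earlier steps shown here concerned configuration alone, whereas this one shows that, with the configuration of compound 1 kept, this methoxy group and the hydrogen-bond acceptor counted with it are not needed for the read-out, and that the number moves down beyond the scatter when fluoro enters. Nothing at hand on these compounds gives a reason for this step, so it stands as an observation on a single pair.

The compounds shown leave open whether this gain is particular to fluoro or would also appear with chloro, a hydroxy group, a trifluoromethyl group or plain hydrogen at this place, and whether the remaining methoxy group can be exchanged in the same way. They also leave open whether fluoro at this place would change the read-out at all in the configurations drawn for compound 2 and compound 3, as only one compound with a changed aromatic ring is shown.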